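The compounds below may be only part of what the source reports. "The series", "measured", "known", "first", "only" and "open" are said of these compounds alone.

In a functional assay on MCF7 cells (Homo sapiens) for antiproliferative activity, read by XTT assay, with a stated time of 72 h (on this read-out higher numbers stand for weaker inhibition and lower numbers for stronger inhibition), compound 2 `COc1ccc(-c2cc3ccccc3nc2/C=C/C(=O)c2ccccc2)cc1` gives 4040 nM, the highest of the two numbers measured; the nearest is compound 3 `COc1ccc(-c2cc3ccccc3nc2/C=C/C(=O)c2cccs2)cc1`, which gives 1030 nM. Compound 1 `COc1ccc(-c2cc3ccccc3nc2C=O)cc1` gives only a limit of this assay, > 10000 nM. Compound 4 `COc1ccc(-c2cc3ccccc3nc2/C=C/C(=O)c2ccc[nH]2)cc1` is not yet measured and differs from compound 2 in one place: 1H-pyrrol-2-yl in place of phenyl on a carbonyl carbon. The measured step that bears most on this change is a 3.9-fold lower number from compound 2 to compound 3 (0.59 log units; beyond the scatter), which also replaced the phenyl on the carbonyl carbon with a five-membered aromatic ring with one hetero atom. The larger step of an at least 9.7-fold lower number from compound 1 to compound 3 (0.98 log units; beyond the scatter) altered a different part of the structure. A modest lowering in this assay is therefore expected, a 2.7-fold lower number from compound 2 to compound 4 (0.43 log units; beyond the scatter). Compound 4 is estimated at 1500 nM, between 500 nM and 4500 nM.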

Compound 4, half-maximal inhibitory concentration: > 10000 nM
Compound 4 ended at the assay's limit; the forecaster's own chance of this, stated with the estimate: 5%; at least 6.6-fold (0.82 log units) between middle value and limit.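

In this assay, the 1H-pyrrol-2-yl group gives an at least 2.4-fold higher number from compound 2 to compound 4 (0.39 log units; beyond the scatter), so a five-membered aromatic ring on this carbonyl carbon does not by itself lower the number, as thiophen-2-yl did in compound 3. The two five-membered rings also part sharply, with an at least 9.7-fold higher number from compound 3 to compound 4 (0.98 log units; beyond the scatter), so the identity of the ring matters here, not just its size. The step from compound 1 to compound 4 cannot be read because both values are limits: the limit of > 10000 nM in this assay, at which 2 of the 4 values shown sit.

Open, from the compounds shown here alone, is how furan-2-yl or 1-methyl-1H-pyrrol-2-yl would behave on this carbonyl carbon, and so whether the hydrogen on the ring nitrogen is what separates compound 4 from compound 3.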